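Selenium to sulfur on the shared core

A few compounds are considered here, and "the series" means these few. Any claim that something is new, unique, unknown or untested is made for them only; others in the source may bear on it.

Measured compounds:
compound 1 `C[Se]/C(=N\C(=O)c1cccs1)NC(=O)c1cccs1`: 5640 nM
compound 2 `CS/C(=N\C(=O)c1ccno1)NC(=O)c1ccno1`: > 100000 nM
compound 3 `C[Se]/C(=N\C(=O)c1sccc1Cl)NC(=O)c1sccc1Cl`: 31200 nM

In a functional assay on MCF7 cells (Homo sapiens) for cytotoxicity, read by MTT assay, with a stated time of 72 h (on this read-out lower numbers stand for stronger inhibition of growth and higher numbers for weaker inhibition of growth), compound 1 gives 5640 nM and compound 3 gives 31200 nM, so compound 3 holds the higher of the two numbers, a gap beyond the usual scatter. For compound 2 the assay reports only a limit, > 100000 nM, not a number. Compound 4 `CS/C(=N\C(=O)c1sccc1Cl)NC(=O)c1sccc1Cl` differs from compound 3 by a group of 2 heavy atoms (1 carbon, 1 sulfur; no ring) in place of a group of 2 heavy atoms (1 carbon, 1 selenium; no ring), on a carbon with a double bond to nitrogen. Going by the values given here, no measured pair isolates this change, and compound 2, which also carries methylsulfanyl though on a different core, reached only a limit. The step from compound 3 to compound 4 is therefore expected to be a 2.2-fold higher number from compound 3 to compound 4 (0.35 log units; beyond the scatter), towards weaker growth inhibition. Compound 4 is estimated at 70000 nM, within a range of 20000 nM to 250000 nM.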

Compound 4, concentration for total growth inhibition: 57100 nM
Estimate against measurement, compound 4: 1.2-fold (0.09 log units) above; the measured number falls inside the stated range.
By their numbers in this assay, from the lowest: compound 1; then compounds 3 and 4 (each within the scatter of the next). At a limit, above all of these: compound 2.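

In this assay, this is the only pair shown that isolates selenium against sulfur on one core: replacing the selenium-bearing group with methylsulfanyl, on a carbon with a double bond to nitrogen, gives a 1.8-fold higher number from compound 3 to compound 4 (0.26 log units; within the scatter). On this core, then, the change does not separate the two compounds. No measurement shown gives a cause for this step.

On these data alone, whether the same holds on the core of compound 1 stays open. So does the effect of an amine or a longer chain in place of methylsulfanyl on this carbon.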